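The source may report more compounds than this note shows. Statements on the series, on what has been measured and on what is new or still open speak of the compounds shown alone.

In a functional assay on MDA-MB-231 cells (Homo sapiens) for antiproliferative activity, read by sulforhodamine B assay, with a stated time of 48 h (on this read-out lower numbers stand for stronger inhibition and higher numbers for weaker inhibition), compound 2 (`COc1ccc(C(=O)/C=C\Nc2ccc(-c3nc4cc(OC)c(OC)c(OC)c4s3)cc2C)cc1O`) gives 12400 nM. Compound 3 (`COc1ccc2nc(-c3ccc(N/C=C\C(=O)c4ccc(OC)c(O)c4)c(C)c3)sc2c1`) lies within the scatter of that at 14000 nM, while compound 1 (`COc1cc(OC)c2sc(-c3ccc(N/C=C\C(=O)c4ccc(OC)c(O)c4)c(C)c3)nc2c1`) reads clearly lower at 3100 nM. Compound 4 (`COc1ccc(C(=O)/C=C\Nc2ccc(-c3nc4cc(OC)c(OC)c(OC)c4s3)cc2C)cc1[N+](=O)[O-]`) alters one group of compound 2: nitro in place of hydroxy on an aromatic carbon. In words, nitro replaces hydroxy on an aromatic carbon, turning 3-hydroxy-4-methoxyphenyl into 4-methoxy-3-nitrophenyl. Among the compounds with values here, the only measured step, a 4.0-fold higher number from compound 1 to compound 2 (0.60 log units; beyond the scatter), adds a methoxy to the shared core, so it bears on this swap only weakly. Within the data shown here, no measured compound varies the hydroxy, and no direction can be argued. The expected change is a 1.1-fold lower number from compound 2 to compound 4 (0.05 log units; within the scatter), nothing beyond the scatter. For compound 4 the estimated value is 11000 nM, with an expected range from 3500 nM to 32000 nM.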

Compound 4, half-maximal inhibitory concentration: 12400 nM
Estimate against measurement, compound 4: 1.1-fold (0.05 log units) below; the measured number falls inside the stated range.
By their numbers in this assay, from the lowest: compound 1; then compounds 2, 4 and 3 (each within the scatter of the next).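

In this assay, putting nitro in place of the hydroxy on the 3-hydroxy-4-methoxyphenyl group gives no change at the digits printed from compound 2 to compound 4 (within the scatter). On this core, then, the read-out does not depend on the hydrogen-bond donor of the hydroxy, and this position accepts the larger nitro group without a visible cost. Nothing available explains why the two groups read alike. As far as these compounds go, whether an amine or a carboxylic acid at this position would also read the same stays open, as does whether the swap behaves this way on the cores of compound 1 and compound 3.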